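The source may report more compounds than this note shows. Statements on the series, on what has been measured and on what is new or still open speak of the compounds shown alone.

The compounds share one amide-linked core. Compound 1 `Cc1cc(NC(=O)c2ccc(Cl)c([N+](=O)[O-])c2)ccc1NS(C)(=O)=O` carries a nitro group on the benzoyl side; compound 2 `CCS(=O)(=O)Nc1ccc(NC(=O)c2ccc(Cl)cc2)cc1C` lacks it; compound 3 `CCS(=O)(=O)Nc1ccc(NC(=O)c2ccc(C#N)cc2)cc1C` replaces the chloro of compound 2 with a nitrile. In an ADME assay on HEK293 cells (Homo sapiens) for cytotoxicity, read by MTT assay, with a stated time of 48 h (a higher number here means a weaker inhibitor, a lower number a stronger inhibitor), compound 1 gives 73100 nM, and in this assay compound 2 gives 125000 nM, the two lying within the scatter of each other. For compound 3 the assay reports only a limit, > 250000 nM, so the change an at least 2.0-fold higher number from compound 2 to compound 3 (0.30 log units; that floor lies within the scatter) is known only as a floor (the limit of > 250000 nM in this assay, at which 1 of the 3 values shown sits).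

The step from compound 2 to compound 4 `CCS(=O)(=O)Nc1ccc(NC(=O)c2ccc(Cl)c([N+](=O)[O-])c2)cc1C` is nitro in place of hydrogen on an aromatic carbon. Within the data shown here, no measured step isolates this change: compound 1 differs from compound 2 both in the nitro group and in the methyl in place of ethyl on the sulfonamide, so their two values are all that can be read, and they sit within the scatter. The step from compound 2 to compound 3 concerns a different group and gives only a floor. On this evidence the account expects no step beyond the scatter, a 1.3-fold lower number from compound 2 to compound 4 (0.10 log units; within the scatter), with the chance that compound 4 is reported only as a limit.

The estimate for compound 4 in this assay is therefore 100000 nM, within 40000 nM to 250000 nM.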

Compound 4, half-maximal inhibitory concentration: 144000 nM
The estimate for compound 4 lay 1.4-fold (0.16 log units) below the measured number, within the range that was stated.
By their numbers in this assay, from the lowest: compounds 1, 2 and 4 (each within the scatter of the next). At a limit, above all of these: compound 3.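

Among these compounds, compound 4 gives the first measured step that isolates the nitro group: in this assay, nitro in place of hydrogen on an aromatic carbon, ortho to a chloro group, gives a 1.2-fold higher number from compound 2 to compound 4 (0.06 log units; within the scatter) and so shows that, with the ethyl chain on the sulfonyl sulfur kept, this position takes the nitro group without a step beyond the scatter. Compound 4 also separates the sulfonamide chain from the nitro group, two changes that lay together between compound 1 and compound 2: methyl in place of hydrogen on a saturated chain carbon bound to a sulfonyl sulfur gives a 2.0-fold higher number from compound 1 to compound 4 (0.29 log units; within the scatter) and this step, too, stays within the scatter. The data shown give no cause for either step.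

Going by these compounds, whether an amine or a carboxylic acid at this position would also stay within the scatter remains open, as does the effect of a longer chain on the sulfonyl sulfur. On these data alone, for compound 3 the value > 250000 nM is a limit, so the full size of its step remains open.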